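The compounds below may be only part of what the source reports. "The series", "measured", "known", "first", "only" and "open" are said of these compounds alone.

Working notes on the amide series. Of the compounds shown here, three have been measured in a functional assay on HepG2 cells (Homo sapiens) for cytotoxicity, read by MTT assay, with a stated time of 72 h; on this read-out lower numbers stand for stronger inhibition and higher numbers for weaker inhibition. Compound 1 `CN1[C@@H]2c3[nH]c4ccccc4c3C[C@H]1[C@H](C#N)N1[C@@H](CNC(=O)c3cccc(C(F)(F)F)c3)c3[nH]c4ccccc4c3C[C@@H]21` gives 340 nM, compound 2 `CN1[C@@H]2c3[nH]c4ccccc4c3C[C@H]1[C@H](C#N)N1[C@@H](CNC(=O)c3ccc(F)cc3)c3[nH]c4ccccc4c3C[C@@H]21` gives 210 nM, and compound 3 `CN1[C@@H]2c3[nH]c4ccccc4c3C[C@H]1[C@H](C#N)N1[C@@H](CNC(=O)c3cccc4c3CCCC4)c3[nH]c4ccccc4c3C[C@@H]21` gives 540 nM. Compound 3 holds the highest number of the three: the step of a 1.6-fold higher number from compound 1 to compound 3 (0.20 log units; within the scatter) is small, while a 2.6-fold higher number from compound 2 to compound 3 (0.41 log units; beyond the scatter) is modest. Compound 4 `CN1[C@@H]2c3[nH]c4ccccc4c3C[C@H]1[C@H](C#N)N1[C@@H](CNC(=O)c3ccc4ccccc4n3)c3[nH]c4ccccc4c3C[C@@H]21` differs from compound 3 by quinolin-2-yl in place of 1,2,3,4-tetrahydronaphthalen-5-yl on a carbonyl carbon. Within the data shown here, the steps that bear on this change are the other aryl swaps on the carbonyl carbon, a 1.6-fold lower number from compound 1 to compound 2 (0.21 log units; within the scatter) together with the two above, all of them small. A step of similar size, if any, is therefore expected in this assay , more likely toward a lower number since compound 3 stands highest at 540 nM. The expected step is a 1.5-fold lower number from compound 3 to compound 4 (0.19 log units; within the scatter). Compound 4 is estimated at 350 nM, with a range from 150 nM to 900 nM.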

Compound 4, half-maximal inhibitory concentration: 110 nM
Compound 4: the middle estimate sits 3.2-fold (0.50 log units) above what was measured; measured number outside the range, below it.
By their numbers in this assay, from the lowest: compounds 4, 2, 1 and 3 (each within the scatter of the next, the first and the last beyond it).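

In this assay, the group on the carbonyl carbon now gives steps beyond the scatter from two compounds: quinolin-2-yl gives a 4.9-fold lower number from compound 3 to compound 4 (0.69 log units; beyond the scatter) against 1,2,3,4-tetrahydronaphthalen-5-yl and a 3.1-fold lower number from compound 1 to compound 4 (0.49 log units; beyond the scatter) against 3-(trifluoromethyl)phenyl. Against 4-fluorophenyl, it gives a 1.9-fold lower number from compound 2 to compound 4 (0.28 log units; within the scatter), so compound 2 and compound 4 are not separated. Nothing available explains these differences.

The change from compound 3 to compound 4 replaces the non-aromatic ring and adds the ring nitrogen together, so their separate contributions remain unresolved. As far as these compounds go, how a naphthalen-2-yl group or a longer alkyl chain on the carbonyl carbon would read also remains open.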